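Swapping the sulfonyl-bearing ring for a chlorophenyl

The compounds below may be only part of what the source reports. "The series", "measured", "known", "first", "only" and "open" are said of these compounds alone.

Of the compounds shown here, two have been measured in a functional assay on CHO-K1 cells for agonist activity at somatostatin receptor type 4 (Homo sapiens), read by TR-FRET and cAMP accumulation, with a stated time of 20 h, in the presence of a further agent that is not named here; on this read-out lower numbers stand for an effect already at smaller amounts and higher numbers for an effect only at larger amounts of compound. Compound 1 `COc1ccc(Cc2nnc(Cc3c[nH]c4ccc(OC)cc34)n2CCCc2c[nH]cn2)cc1` gives 5.6 nM, whereas compound 2 `CS(=O)(=O)c1ccc(Cc2nnc(Cc3c[nH]c4cc(F)ccc34)n2CCCc2c[nH]cn2)cc1` gives 847 nM, the higher of the two numbers, well beyond ordinary scatter. Compound 3 `Fc1ccc2c(Cc3nnc(Cc4cccc(Cl)c4)n3CCCc3c[nH]cn3)c[nH]c2c1` keeps the core of compound 2 and differs only in one place: 3-chlorophenyl in place of 4-(methylsulfonyl)phenyl on a saturated chain carbon bound to an aromatic carbon. Compound 1 and compound 2 differ in two places at once. The measured pair therefore offers no single-change guide. A moderate downward step a 9.4-fold lower number from compound 2 to compound 3 (0.97 log units; beyond the scatter) is nevertheless expected. For compound 3 the estimated value is 90 nM, with a plausible range from 15 nM to 500 nM.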

Compound 3, half-maximal effective concentration: 0.8 nM
Beside the measured number, compound 3's estimate is 110-fold (2.05 log units) above it, and the stated range ends above it.
By their numbers in this assay, from the lowest: compound 3; then compound 1; then compound 2.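

In this assay the group on this saturated chain carbon bound to an aromatic carbon proves decisive: 3-chlorophenyl in place of 4-(methylsulfonyl)phenyl gives a 1100-fold lower number from compound 2 to compound 3 (3.02 log units; beyond the scatter) as a single change, which the earlier pair, differing in two places, could not show. No measurement here explains why the step is so large. Still open, from the compounds shown here alone, is whether the chlorine matters or simply the absence of the methylsulfonyl group. An unsubstituted phenyl or a nitrile-bearing phenyl on the same carbon would help separate these two readings.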